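The source may report more compounds than this note shows. Statements on the series, on what has been measured and on what is new or still open speak of the compounds shown alone.

Compound 1 `O=S(=O)(Nc1cccc(CO)c1)c1ccc(-c2ccc(Cl)cc2)cc1`: in a functional assay on J774 cells (Mus musculus) for cytotoxicity, read by resazurin assay, with a stated time of 72 h (a higher number here means a weaker inhibitor, a lower number a stronger inhibitor), compound 1 gives 2500 nM.
Compound 2 `CN(C)c1ccc(-c2ccc(S(=O)(=O)Nc3cccc(CO)c3)cc2)cc1`: in this assay compound 2 gives only a limit, > 5000 nM.
Compound 3 `Cc1ccc(-c2ccc(S(=O)(=O)Nc3cccc(CO)c3)cc2)cc1`: in this assay compound 3 gives 1200 nM.

Compound 3 holds the lowest of the two numbers; compound 1 is nearest, the two separated by a 2.1-fold lower number from compound 1 to compound 3 (0.32 log units; beyond the scatter). Compound 2 sits at the limit (the limit of > 5000 nM in this assay, at which 1 of the 3 values shown sits), so the step of an at least 4.1-fold lower number from compound 2 to compound 3 (0.61 log units; beyond the scatter) is a floor only.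

Compound 4 `O=S(=O)(Nc1cccc(CO)c1)c1ccc(-c2ccc(Cl)cc2F)cc1` differs from compound 3 by 4-chloro-2-fluorophenyl in place of 4-methylphenyl on an aromatic carbon. Among the measured compounds shown here, the step of a 2.1-fold lower number from compound 1 to compound 3 (0.32 log units; beyond the scatter), read in reverse, is the only measured guide; the added fluorine has no measured counterpart here. A modest rise is therefore expected, a 2.1-fold higher number from compound 3 to compound 4 (0.32 log units; beyond the scatter). Compound 4 is estimated at 2500 nM, within 1000 nM to 6000 nM.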

Compound 4, half-maximal inhibitory concentration: 700 nM
The estimate for compound 4 lay 3.6-fold (0.55 log units) above the measured number; the whole stated range lies above it.
By their numbers in this assay, from the lowest: compounds 4 and 3 (each within the scatter of the next); then compound 1. At a limit, above all of these: compound 2.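

Fluoro in place of hydrogen on an aromatic carbon, with the chloro kept, gives a 3.6-fold lower number from compound 1 to compound 4 (0.55 log units; beyond the scatter), so this position responds to a change other than replacing the chloro. Compound 3 and compound 4 cannot be separated, with a 1.7-fold lower number from compound 3 to compound 4 (0.23 log units; within the scatter), so 4-chloro-2-fluorophenyl and 4-methylphenyl read alike here. Compound 2 stands at a limit, so an at least 7.1-fold lower number from compound 2 to compound 4 (0.85 log units; beyond the scatter) is a floor only: the limit of > 5000 nM in this assay, at which 1 of the 4 values shown sits.

Still open, from the compounds shown here alone, is how fluoro without the chloro would read in this assay. Also open, going by these compounds, is how a methoxy or nitrile group at the place of the chloro would read.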